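A hydroxy group added to compound 1

The source may report more compounds than this note shows. Statements on the series, on what has been measured and on what is new or still open speak of the compounds shown alone.

Compound 1 (`c1cc(C2=NCCN2)cc(-c2cc3cc(C4=NCCN4)ccc3o2)c1`) has been tested in an ADME assay on L6 cells (Rattus norvegicus) for cytotoxicity (a higher number here means a weaker inhibitor, a lower number a stronger inhibitor), and compound 1 gives 33900 nM there. Going by the values given here, this is the only exact number so far. Compound 2 (`N=C(N)c1ccc(O)c(-c2cc3cc(C(=N)N)ccc3o2)c1`) reads > 217000 nM in the same test, and that reading is a limit of the assay, not a number.

The next compound is compound 3 (`Oc1ccc(C2=NCCN2)cc1-c1cc2cc(C3=NCCN3)ccc2o1`). It is compound 1 with one change (hydroxy in place of hydrogen on an aromatic carbon): hydroxy in place of hydrogen on an aromatic carbon, ortho to a large group and para to a group of 5 heavy atoms. Among the compounds with values here, no two measured compounds differ in just one place, so the size of this step has not been seen directly.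

Compound 2 also carries a hydroxy, and its limit of > 217000 nM gives a weak reason to expect movement toward weaker inhibition in this assay. A modest step is expected (a 1.8-fold higher number from compound 1 to compound 3 (0.25 log units; within the scatter)), though one within the scatter remains possible. For compound 3 the estimated value is 60000 nM with an expected range of 20000 nM to 200000 nM in this test.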

Compound 3, half-maximal inhibitory concentration: > 199000 nM
Compound 3 was reported as a limit; the forecaster's own chance of this, stated with the estimate: 25%; middle value at least 3.3-fold (0.52 log units) from the limit.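

Going by these compounds alone, this is the first direct look at this position, and it shows that a single hydroxy in place of hydrogen on an aromatic carbon, ortho to a large group and para to a group of 5 heavy atoms, is enough to give an at least 5.8-fold higher number from compound 1 to compound 3 (0.76 log units; beyond the scatter) in this assay. The change adds only one oxygen atom to the core of compound 1, yet the step lies beyond the usual scatter, so this small edit clearly moves the compound toward weaker inhibition in this cell test. Only the lowest possible size of the step is known, and its full size stays unknown because the reading for compound 3 is a limit of the assay and not a number: the limit of > 199000 nM in this assay, at which 1 of the 3 values shown sits.

The compounds shown do not tell whether the oxygen itself matters here, or whether a methoxy group, a fluorine atom or an amine at the same carbon would shift the number in the same way. They also leave open whether a hydroxy on another carbon of this six-membered ring would give a similar step, and what lies behind the step at all.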